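Swapping the Thiazole for a Dimethylpyridine in Compound 1

The compounds below may be only part of what the source reports. "The series", "measured", "known", "first", "only" and "open" are said of these compounds alone.

Measured so far:
- compound 1, `Cc1csc(N/C(S)=N/[C@@H](C)c2cccc3ccccc23)n1`: 83200 nM
- compound 2, `CCOC(=O)Cc1csc(/N=C(\S)N[C@H](C)c2cccc3ccccc23)n1`: 2 nM
- compound 3, `CCOC(=O)Cc1csc(/N=C(\S)N[C@@H](C)c2cccc3ccccc23)n1`: 9 nM

In a functional assay on RBL-2H3 cells (Rattus norvegicus) for inhibition (a lower number here means a stronger inhibitor, a higher number a weaker inhibitor), compound 1 gives 83200 nM, the highest of the three numbers, far removed from compound 3 and from compound 2. Going by the values given here, the only step between compounds that differ in one place is a 4.5-fold higher number from compound 2 to compound 3 (0.65 log units; beyond the scatter), which rests on the fact that compounds 2 and 3 differ only in the configuration as drawn and therefore says nothing about the change considered here.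

Compound 4, `Cc1cc(C)nc(N/C(S)=N/[C@@H](C)c2cccc3ccccc23)c1`, follows from compound 1 by the change (4,6-dimethylpyridin-2-yl in place of 4-methyl-1,3-thiazol-2-yl on an amine nitrogen). Among the compounds with values here, no measured pair shows this kind of swap, so the expectation can lean only on where compound 1 stands. Within the data shown here, with no step to guide direction, the number for compound 4 is expected to stay near that of compound 1, with a step of a 1.4-fold lower number from compound 1 to compound 4 (0.14 log units; within the scatter) that could fall on either side of the scatter. Compound 4 is therefore estimated at 60000 nM, in a wide range from 8000 nM to 300000 nM, reflecting that the shared core here has so far only been seen with a thiazole attached.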

Compound 4, half-maximal inhibitory concentration: > 100000 nM
Compound 4 was reported as a limit (the forecaster's own chance of this, stated with the estimate: 25%); middle value at least 1.6-fold (0.22 log units) away from the limit.
By their numbers in this assay, from the lowest: compound 2; then compound 3; then compound 1. At a limit, above all of these: compound 4.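

In this assay compound 4 gives > 100000 nM, which is a limit of the assay and not a number. The step, an at least 1.2-fold higher number from compound 1 to compound 4 (0.07 log units; that floor lies within the scatter), has a floor that lies within the scatter, so the data do not establish that compound 4 is a weaker inhibitor than compound 1, and the true size of the step cannot be read: the limit of > 100000 nM in this assay, at which 1 of the 4 values shown sits. What this adds is a first look at a ring other than a thiazole on this amine nitrogen: replacing 4-methyl-1,3-thiazol-2-yl with 4,6-dimethylpyridin-2-yl, a six-membered aromatic ring, brings back no measurable inhibition, and the reason is not shown by these compounds.

As far as these compounds go, compound 4 carries only methyl groups on its ring, so it remains open whether a pyridine ring could work at all when it bears the ethyl ester side chain found in compound 2 and compound 3. Also open, from the compounds shown here alone, is what a carboxylic acid or a primary amine on either ring would do to the number in this assay.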